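A few compounds are considered here, and "the series" means these few. Any claim that something is new, unique, unknown or untested is made for them only; others in the source may bear on it.

Of the compounds shown here, three sharing one core have been measured in a functional assay on KYSE-450 cells (Homo sapiens) for inhibition, read by CCK-8 assay, with a stated time of 48 h; on this read-out higher numbers stand for weaker inhibition and lower numbers for stronger inhibition. Compound 1 `COc1cc(N(Cc2ccc(Br)cc2)C(=O)CSC(=S)N2CCN(C(=O)OC(C)(C)C)CC2)cc(OC)c1OC` gives 10700 nM, compound 2 `COc1ccc(CN(C(=O)CSC(=S)N2CCN(C(=O)OC(C)(C)C)CC2)c2cc(OC)c(OC)c(OC)c2)cc1Br` gives 1850 nM, and compound 3 `COc1ccc(CN(C(=O)CSC(=S)N2CCN(C(=O)OC(C)(C)C)CC2)c2cc(OC)c(OC)c(OC)c2)cc1N` gives 208 nM. Compound 3 therefore has the lowest number of the three, and it is the strongest inhibitor of this set, with both of its gaps beyond the scatter. The next structure, compound 4 `COc1ccc(CN(C(=O)CSC(=S)N2CCN(C(=O)OC(C)(C)C)CC2)c2cc(OC)c(OC)c(OC)c2)cc1O`, carries hydroxy in place of amino on an aromatic carbon, ortho to a methoxy group and meta to a large group: hydroxy in place of amino on an aromatic carbon. Among the compounds with values here, no measured compound carries hydroxy, so no step measures this exchange directly. The closest evidence is an 8.9-fold lower number from compound 2 to compound 3 (0.95 log units; beyond the scatter), a modest step made at the same aromatic carbon, which shows that the group there can move the number. The steps of a 5.8-fold lower number from compound 1 to compound 2 (0.76 log units; beyond the scatter) and a 51-fold lower number from compound 1 to compound 3 (1.71 log units; beyond the scatter) also bear on the question, though each changes the benzyl group more broadly, and the second is large. Against that background, the exchange of amino for hydroxy is expected to matter much less than the exchange of bromo for amino, with a slight lean towards weaker inhibition. The expected change is a 1.3-fold higher number from compound 3 to compound 4 (0.13 log units; within the scatter), which would lie within the scatter. For compound 4 the estimated value is 280 nM, with an expected range from 90 nM to 900 nM.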

Compound 4, half-maximal inhibitory concentration: 76 nM
The estimate for compound 4 lay 3.7-fold (0.57 log units) above the measured number; the measured number lies below the stated range.
By their numbers in this assay, from the lowest: compound 4; then compound 3; then compound 2; then compound 1.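

In this assay, within the data shown here, the carbon ortho to a methoxy group and meta to a large group had so far been read only with bromo and amino, and a 2.7-fold lower number from compound 3 to compound 4 (0.44 log units; beyond the scatter) shows that the number there still moves beyond the scatter when amino gives way to hydroxy, although the counts of heavy atoms, hydrogen-bond donors and hydrogen-bond acceptors stay the same. Measured against bromo on the same carbon, the exchange gives a 24-fold lower number from compound 2 to compound 4 (1.39 log units; beyond the scatter) and is large where the amino exchange was modest, while the broader change of the benzyl group gives a 140-fold lower number from compound 1 to compound 4 (2.15 log units; beyond the scatter) and sets the widest gap in the series. No measurement of any property of these groups accompanies the result, so the order at this carbon stands without an explanation.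

The compounds shown leave open whether the hydrogen of the hydroxy matters, which a methoxy on this carbon would test, and how a plain hydrogen there would compare. They also leave open whether the same order would hold with a free amine in place of the tert-butyl carbamate.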